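The compounds below may be only part of what the source reports. "The series", "measured", "known", "first", "only" and "open" are said of these compounds alone.

Measured so far:

Compound 1, `COc1cc(C(=O)N/N=C/c2ccccc2F)cc(OC)c1OC`: 81.8%
Compound 2, `COc1cc(C2=NN(C(C)=O)C(c3cc(OC)c(OC)c(OC)c3)O2)cc(OC)c1OC`: 0.1%
Compound 3, `COc1cc(C2=NN(C(C)=O)C(c3cc(Cl)cc(Cl)c3)O2)cc(OC)c1OC`: 93.9%

These three compounds were tested in a functional assay on PC-3 cells (Homo sapiens) for antiproliferative activity, read by MTT assay, tested at 5 uM; a lower number here means a weaker effect, a higher number a stronger effect of the compound at the concentration tested. Compound 1 stands second highest of the three numbers. Compound 3 sits nearest to it, with a number higher by a gap that lies beyond the usual scatter, so compound 3 gives the stronger effect of the two. Compound 2 lies furthest away: in this assay compound 2 gives 0.1%, a number far lower than that of compound 1, a gap well beyond the scatter, so compound 2 shows almost no effect at the concentration tested.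

The next compound, compound 4, `COc1cc(C(=O)N/N=C/c2c(Cl)cccc2Cl)cc(OC)c1OC`, has not yet been measured in this assay. It differs from compound 1 in one place:

2,6-dichlorophenyl in place of 2-fluorophenyl on a carbon with a double bond to nitrogen

Going by the values given here, no measured pair in this set differs in one place only, so there is no measured step to lean on. Compound 1 already gives a high number in this assay, and compound 3, which carries two chlorine atoms on its phenyl ring, gives 93.9%. On that basis, the expected step of a number 4.2 percentage points higher from compound 1 to compound 4 (within the scatter) from compound 1 to compound 4 is small and upward, likely within the scatter. Compound 4 is therefore estimated to give 86%, in a range from 62% to 97%.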

Compound 4, a percentage reported as inhibition, at one concentration (the size of the read-out at that concentration, not a potency): 52.1%
Beside the measured number, compound 4's estimate is 33.9 percentage points above it; measured number outside the range, below it.
By their numbers in this assay, from the lowest: compound 2; then compound 4; then compound 1; then compound 3.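

Going by these compounds alone, this is the first step in the set that changes one place alone, and it shows that the group on the carbon with a double bond to nitrogen shapes the result in this assay: putting 2,6-dichlorophenyl in place of 2-fluorophenyl gives a number 29.7 percentage points lower from compound 1 to compound 4 (beyond the scatter). The position is therefore sensitive to which substituted phenyl group it carries, yet the change does not abolish the effect, as compound 4 still gives 52.1% at the single concentration tested, a read-out of effect size rather than a potency. Nothing shown here explains the drop.

The change alters both the kind of halogen and the number of halogen atoms on the ring, so this one step cannot separate the two, and a compound carrying 2-chlorophenyl or 2,6-difluorophenyl at this position would help to pull them apart. Also open, on these data alone, is how the same position responds to a group without any halogen, such as 2-methoxyphenyl, or to a ring bearing an amine or a carboxylic acid.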